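Two measured compounds and a third awaiting its number

The compounds below may be only part of what the source reports. "The series", "measured", "known", "first", "only" and "open" are said of these compounds alone.

Both measured compounds were tested in a functional assay on HepG2 cells (Homo sapiens) for antiproliferative activity, read by MTT assay, with a stated time of 48 h; on this read-out higher numbers stand for weaker inhibition and lower numbers for stronger inhibition:

Compound 1 `Clc1cccc(Nc2ncnc3ccc(NCc4c[nH]c5ccccc45)cc23)c1`: 5260 nM
Compound 2 `O=C(/C=C/c1cccnc1)Nc1ccc2ncnc(Nc3cccc(Cl)c3)c2c1`: 9120 nM

In this assay compound 2 and compound 1 give numbers that lie within the usual scatter of each other, so on the numbers shown compound 2 cannot be separated from compound 1; the two stand as a pair. Compound 3 `O=C(/C=C/c1ccc(Br)s1)Nc1ccc2ncnc(Nc3cccc(Cl)c3)c2c1` differs from compound 2 in one place: 5-bromothiophen-2-yl in place of pyridin-3-yl on a double-bonded chain carbon bound to a double-bonded chain carbon. Among the measured compounds shown here, no step between two measured compounds bears on this change, so nothing in the data sets its size or direction. The expectation is therefore a step from compound 2 to compound 3 of a 1.3-fold lower number from compound 2 to compound 3 (0.11 log units; within the scatter), not beyond the scatter in either direction. On that basis compound 3 is estimated at 7000 nM in this assay, with a range from 2500 nM to 20000 nM.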

Compound 3, half-maximal inhibitory concentration: 8850 nM
Compound 3: the middle estimate sits 1.3-fold (0.10 log units) below what was measured, within the range that was stated.
By their numbers in this assay, from the lowest: compounds 1, 3 and 2 (each within the scatter of the next).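

Among the compounds shown here, at this place, on a double-bonded chain carbon bound to a double-bonded chain carbon, the exchange of pyridin-3-yl for 5-bromothiophen-2-yl gives the first direct reading in this assay: a 1.0-fold lower number from compound 2 to compound 3 (0.01 log units; within the scatter). The two groups have the same count of heavy atoms but differ in ring size and hetero atom, and here the numbers of the two compounds cannot be separated, so this position accepts either group without a difference that this read-out can resolve. No measurement available here accounts for that outcome.

On these data alone, it remains open whether thiophen-2-yl without the bromine, or a phenyl ring carrying an amine or a carboxylic acid, would also give a number within the scatter of these two. As far as these compounds go, a longer chain between the amide carbonyl and the ring is equally open.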